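The source may report more compounds than this note shows. Statements on the series, on what has been measured and on what is new or still open speak of the compounds shown alone.

Compound 3, `CN/C(=N/C#N)NCCCCCn1ccnc1C`, is one of three compounds with a number in a functional assay on Sf9 cells for antagonist activity at histamine H2 receptor (Homo sapiens), read by scintillation counting and GTPgammaS binding, with a stated time of 90 min; on this read-out higher numbers stand for higher potency (the scale is a negative logarithm) and lower numbers for lower potency. In this assay compound 3 gives < 5, which is a limit of the assay rather than a number. The two compounds around it are compound 1, `Cc1nc(CCCN/C(=N\C#N)NCCSc2ccccc2)c[nH]1`, and compound 2, `Cc1[nH]cnc1CCCCN/C(=N\C#N)NCCSc1ccccc1`. In this assay compound 1 gives < 5, again a limit of the assay. In this assay compound 2 gives 5.36. Within the data shown here, the only measured step between them is a number at least 0.36 log units higher from compound 1 to compound 2 (beyond the scatter), and the fact that the limit of < 5 in this assay, at which 2 of the 3 values shown sit, means the size of that step is known only as a lower bound.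

Compound 4, `Cc1nccn1CCCCCN/C(=N\C#N)NCCSc1ccccc1`, differs from compound 3 by (phenylsulfanyl)methyl in place of hydrogen on a saturated chain carbon bound to an amine nitrogen. Among the measured compounds shown here, no measured step bears on this change directly; compound 2 carries the same (phenylsulfanyl) part as compound 4 and sits a little above the limit, while compound 1 carries it too and sits at the limit. The step from compound 3 to compound 4 is therefore expected to be a number at least 0.20 log units higher from compound 3 to compound 4 (that floor lies within the scatter), no more than modest. Compound 4 is expected to give 5.2 in this assay, between 4.5 and 5.9.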

Compound 4, negative logarithm of the antagonist equilibrium constant: < 5
Compound 4: a limit, no number; the forecaster's own chance of this, stated with the estimate: 40%; middle value at least 0.20 log units from the limit.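

Compound 4 gives < 5 in this assay, a limit and not a number, so the (phenylsulfanyl)methyl group on a saturated chain carbon bound to an amine nitrogen does not bring this compound to a measurable value. Replacing 5-methyl-1H-imidazol-4-yl with (2-methyl-1H-imidazol-1-yl)methyl on a saturated chain carbon, four bonds along the chain from an amine nitrogen, gives a number at least 0.36 log units lower from compound 2 to compound 4 (beyond the scatter). The steps to compound 4 from compound 3 and from compound 1 cannot be read, because both ends of each are limits: the limit of < 5 in this assay, at which 3 of the 4 values shown sit.

From the compounds shown here alone, whether the (phenylsulfanyl)methyl group changes potency at all on this chain stays open. Also open, going by these compounds, is whether a longer chain, or an amine on the phenyl ring of compound 4, would give a number in this assay.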